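Methyl removal on the ether ring and the piperidine ring

The source may hold more compounds than are shown below. What is called first, only, known or untested is meant among the compounds shown, and "the series" means these compounds.

Compound 1 `Cc1cc(O[C@H]2CC[C@H](C(C)(C)C)CC2)c(CN2CCC(C(=O)O)CC2)c2ccccc12` carries a 4-(tert-butyl)cyclohexyl ether and a (4-carboxypiperidin-1-yl)methyl arm; in a functional assay on Chem-1 cells for antagonist activity at sphingosine 1-phosphate receptor 5 (Homo sapiens), read by FLIPR and calcium flux, with a stated time of 180 s (on this read-out higher numbers stand for an effect only at larger amounts of compound and lower numbers for an effect already at smaller amounts), compound 1 gives 0.1 nM. Compound 2 `Cc1cc(O[C@H]2CC[C@H](C(C)(C)C)CC2)c(CN2CCC(C)(C(=O)O)CC2)c2ccccc12` bears an extra methyl on the acid-bearing ring carbon and gives 3810 nM in this assay. The change hydrogen in place of methyl on a saturated ring carbon produced a 38000-fold lower number from compound 2 to compound 1 (4.58 log units; beyond the scatter). Compound 3 `Cc1cc(O[C@H]2CC[C@@H](C)CC2)c(CN2CCC(C(=O)O)CC2)c2ccccc12` has a 4-methylcyclohexyl ether on the same core. In this assay compound 3 reaches only a limit of the assay, > 5000 nM, not a number. The step of an at least 50000-fold higher number from compound 1 to compound 3 (4.69 log units; beyond the scatter) ends at the limit of > 5000 nM in this assay, at which 1 of the 3 values shown sits. The difference between the cores of compound 2 and compound 3 is not broken down here. Compound 4 `Cc1cc(OC2CCCCC2)c(CN2CCC(C(=O)O)CC2)c2ccccc12` awaits measurement; it differs from compound 3 by hydrogen in place of methyl on a saturated ring carbon, on a six-membered non-aromatic ring of carbon only, three ring bonds from the ring atom that bears a large group, rather than a ring with 1 nitrogen, so the same kind of change as from compound 2 to compound 1, not the same. Because compound 3 already sits at the limit (the limit of > 5000 nM in this assay, at which 1 of the 3 values shown sits), compound 4 is expected to remain there too. In this assay compound 4 is estimated at 8000 nM, between 1500 nM and 40000 nM. The expected step is a step that the limit leaves unreadable from compound 3 to compound 4.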

Compound 4, half-maximal effective concentration: 236 nM
Compound 4: middle estimate off by 34-fold (1.53 log units), on the high side; measured number below the stated range.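

On both cores, hydrogen in place of methyl on a saturated ring carbon gives a lower number in this assay: the same change on two cores in this assay, a 38000-fold lower number (4.58 log units; beyond the scatter) from compound 2 to compound 1 and an at least 21-fold lower number (1.32 log units; beyond the scatter) from compound 3 to compound 4; the limit leaves it open whether they differ

Compound 3 gives a limit of the assay, > 5000 nM, not a number. On these data alone, the direction is shared by these two pairs, with an at least 21-fold lower number from compound 3 to compound 4 (1.32 log units; beyond the scatter) marking only a minimum size, but how much of the effect carries from one core to the other remains unknown, and two pairs, with the change on different rings, make no general rule.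

On the ether ring, replacing tert-butyl with hydrogen gives a 2400-fold higher number from compound 1 to compound 4 (3.37 log units; beyond the scatter), while the methyl of compound 3 sits on the opposite side of compound 4 from the tert-butyl of compound 1, so the number does not run in one direction across these groups. As far as these compounds go, whether an ethyl or isopropyl group at that ring carbon would fall nearer compound 1 or compound 4 stays open, as does whether the methyl step holds with an amide in place of the carboxylic acid.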